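The compounds below may be only part of what the source reports. "The series", "measured", "known", "first", "only" and "open" are said of these compounds alone.

Measured so far:
Compound 1, `Cc1ncn2c(Nc3cc[nH]n3)nccc12`: in a functional assay for inhibition, with Homo sapiens as the target (a lower number here means a stronger inhibitor, a higher number a weaker inhibitor), compound 1 gives 57000 nM.
Compound 2, `CCCc1ncn2c(Nc3cc[nH]n3)nccc12`: in this assay compound 2 gives > 48000 nM, which is a limit of the assay and not a number.

Compound 2 therefore stands only as a limit in this assay, with no value of its own on the scale. Among the measured compounds shown here, the single measured step, a step that the limit leaves unreadable from compound 1 to compound 2, cannot be sized because the limit of > 48000 nM in this assay, at which 1 of the 2 values shown sits, caps what is known of compound 2. Compound 3 is `CCc1ncn2c(Nc3cc[nH]n3)nccc12`. It differs from compound 2 by hydrogen in place of methyl on a saturated chain carbon, two bonds along the chain from an aromatic carbon, so it carries an ethyl chain, shorter than the propyl of compound 2 and longer than the methyl of compound 1. For the measured compounds named here, the only step that bears on this change is the unreadable one from compound 1 to compound 2, and both neighbours of compound 3 sit at the weak end of this assay. The step from compound 2 to compound 3 is therefore expected to be a step that the limit leaves unreadable from compound 2 to compound 3, nothing beyond the scatter. Compound 3 is expected to give about 55000 nM in this assay, within a range of 20000 nM to 150000 nM, with a real chance that only a limit is reported.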

Compound 3, half-maximal inhibitory concentration: 36000 nM
Beside the measured number, compound 3's estimate is 1.5-fold (0.18 log units) above it; low and high end bracket the measured number.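

With compound 3, the ethyl chain has a measured number of its own in this assay, which gives the series a second readable value alongside that of the methyl chain of compound 1. Shortening propyl to ethyl gives an at least 1.3-fold lower number from compound 2 to compound 3 (0.12 log units; that floor lies within the scatter), and lengthening methyl to ethyl gives a 1.6-fold lower number from compound 1 to compound 3 (0.20 log units; within the scatter), so the one fully sized change on this chain stays within the scatter, while the other is known only as a floor and its true size may be larger. The step from compound 1 to compound 2 still cannot be read, and compound 2 remains tied to a limit of the assay, not a number: the limit of > 48000 nM in this assay, at which 1 of the 3 values shown sits.

The compounds shown leave open whether any group in place of these chains would move the number beyond the scatter, for instance a butyl chain, an amine or a carboxylic acid. They also leave open how far the propyl chain of compound 2 truly lies from the ethyl chain of compound 3, so no trend with chain length can be drawn from these three compounds.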